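The compounds below may be only part of what the source reports. "The series", "measured", "known", "first", "only" and "open" are said of these compounds alone.

Compound 1 `NC(=O)c1ccc(Oc2cccc(CC(=O)O)c2)c(NS(=O)(=O)c2ccccc2)c1`: 47 nM
Compound 2 `CCNCc1ccc(Oc2cccc(CC(=O)O)c2)c(NS(=O)(=O)c2ccccc2)c1`: gives only a limit of the assay, > 10000 nM

Both compounds were measured in an assay on HEK293 cells for displacement of a labelled ligand from prostaglandin D2 receptor 2 (Homo sapiens), read by scintillation counting, in the presence of a further agent that is not named here; on this read-out lower numbers stand for stronger inhibition and higher numbers for weaker inhibition. Compound 1 gives a number, while compound 2 stands at a limit; that limit is the one described in the limit of > 10000 nM in this assay, at which 1 of the 2 values shown sits, so for compound 2 only a floor is known, and it is the weaker of the two by any reading. Going by the values given here, the single step between them, an at least 210-fold higher number from compound 1 to compound 2 (2.32 log units; beyond the scatter), is large. The next compound to be measured is compound 3 `O=C(O)Cc1cccc(Oc2ccc(Cl)cc2NS(=O)(=O)c2ccccc2)c1`, which differs from compound 2 in one place: chloro in place of (ethylamino)methyl on an aromatic carbon. Among the compounds with values here, the only measured step that bears on this position is the one from compound 1 to compound 2, and it shows that the group at this aromatic carbon can swing the result strongly. Since the (ethylamino)methyl group of compound 2 is the one removed here, compound 3 is expected to move back toward the range of compound 1, giving an estimated step of an at least 200-fold lower number from compound 2 to compound 3 (2.30 log units; beyond the scatter). Compound 3 is therefore estimated at 50 nM, with a likely range from 10 nM to 300 nM.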

Compound 3, half-maximal inhibitory concentration: 680 nM
The estimate for compound 3 lay 14-fold (1.13 log units) below the measured number; the whole stated range lies below it.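

In this assay, going by these compounds, the change to chloro gives an at least 14-fold lower number from compound 2 to compound 3 (1.16 log units; beyond the scatter), so a group of 1 heavy atom, with 0 hydrogen-bond donors and 0 hydrogen-bond acceptors, on this aromatic carbon still leaves a measurable number, and the full size of this gain stays unknown since compound 2 stands at a limit of the assay: the limit of > 10000 nM in this assay, at which 1 of the 3 values shown sits. Chloro does not make up for the loss of carbamoyl, however, and the comparison at the same carbon gives a 14-fold higher number from compound 1 to compound 3 (1.16 log units; beyond the scatter). The position therefore separates three groups rather than two, with carbamoyl giving the lowest number, chloro an intermediate one and (ethylamino)methyl the highest, each step lying beyond the usual scatter.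

These three compounds leave open which feature of carbamoyl gives it the advantage over chloro, and whether the nitrogen or the ethyl chain of the (ethylamino)methyl group matters more for its poor result. On these data alone, how a primary amine, a carboxylic acid or a simple methyl group on this carbon would rank against these three groups remains unknown.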